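Sulfonyl aryl swap on the piperazine series

The source may hold more compounds than are shown below. What is called first, only, known or untested is meant among the compounds shown, and "the series" means these compounds.

Measured compounds:
compound 1, `CCN(CC)c1ccc2cc(C(=O)c3ccc(N4CCN(C(=O)CN5CCN(C(=O)CCl)CC5)CC4)cc3)oc2c1`; in a functional assay on MCF7 cells (Homo sapiens) for cytotoxicity, read by MTT assay, with a stated time of 48 h (on this read-out lower numbers stand for stronger inhibition and higher numbers for weaker inhibition), compound 1 gives only a limit, > 40000 nM.
compound 2, `CCN(CC)c1ccc2cc(C(=O)c3ccc(N4CCN(C(=O)CN5CCN(C(=O)/C=C/c6ccccc6)CC5)CC4)cc3)oc2c1`; in this assay compound 2 gives 13400 nM.
compound 3, `CCN(CC)c1ccc2cc(C(=O)c3ccc(N4CCN(C(=O)CN5CCN(S(=O)(=O)c6ccc(C(F)(F)F)cc6)CC5)CC4)cc3)oc2c1`; in this assay compound 3 gives 17500 nM.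

Compound 3 holds the highest of the two numbers, and its nearest neighbour is compound 2, a gap that stays within the scatter. Among the compounds with values here, the one value of compound 1 is a limit of the assay (the limit of > 40000 nM in this assay, at which 1 of the 3 values shown sits).

Within the data shown here, the only measured step is an at least 2.9-fold lower number from compound 1 to compound 2 (0.47 log units; beyond the scatter), a change on a carbonyl carbon. It says nothing about the aryl group of the sulfonamide.

Compound 4, `CCN(CC)c1ccc2cc(C(=O)c3ccc(N4CCN(C(=O)CN5CCN(S(=O)(=O)c6ccc(F)cc6)CC5)CC4)cc3)oc2c1`, differs from compound 3 by fluoro in place of trifluoromethyl on an aromatic carbon. Among the measured compounds shown here, no measured pair changes this position, so no step beyond the scatter is expected for the move from compound 3 to compound 4: the estimated change is no change at the digits printed from compound 3 to compound 4 (within the scatter).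

Compound 4 is therefore expected to give about 17500 nM in this assay, within a range from 7000 nM to 40000 nM, with some chance that only a limit is reported.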

Compound 4, half-maximal inhibitory concentration: 20500 nM
Compound 4: the middle estimate sits 1.2-fold (0.07 log units) below what was measured; the range from low to high includes it.
By their numbers in this assay, from the lowest: compounds 2, 3 and 4 (each within the scatter of the next). At a limit, above all of these: compound 1.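

In this assay, within the data shown here, fluoro in place of trifluoromethyl on this aromatic carbon, para to a large group, gives a 1.2-fold higher number from compound 3 to compound 4 (0.07 log units; within the scatter), so the first measured step at this position does not separate the two groups. Placing (4-fluorophenyl)sulfonyl on the ring amine nitrogen in place of (2-phenylethenyl)carbonyl gives a 1.5-fold higher number from compound 2 to compound 4 (0.18 log units; within the scatter), so this pair is not separated either. In place of (chloromethyl)carbonyl, the same group gives an at least 1.9-fold lower number from compound 1 to compound 4 (0.29 log units; that floor lies within the scatter), and the value of compound 1 is only a limit: the limit of > 40000 nM in this assay, at which 1 of the 4 values shown sits.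

From the compounds shown here alone, whether an amine, a carboxylic acid or a methoxy group on this aromatic carbon would give a step beyond the scatter remains open. Also open, going by these compounds, is how a plain phenyl or a longer chain in place of the aryl group on the sulfonyl would read.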